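Aryl exchange on the sulfonyl sulfur: compound 2 to 4

The source may report more compounds than this note shows. Statements on the series, on what has been measured and on what is new or still open speak of the compounds shown alone.

Compound 2 `CC(C)Cc1cc(CNS(=O)(=O)c2cccc3ccccc23)nn1-c1ccccc1` gives 2430 nM in a functional assay on HeLa cells for antagonist activity at 5-hydroxytryptamine receptor 6 (Homo sapiens), read by HTRF and cAMP accumulation, with stated times of 10 min and 30 min; a lower number here means a stronger inhibitor, a higher number a weaker inhibitor. Among the three numbers to hand, compound 2 stands second highest: compound 1 `CC(C)Cc1cc(CNS(=O)(=O)c2cccc(Cl)c2)nn1-c1ccccc1` gives 10900 nM, and compound 3 `O=C1c2[nH]nc(NS(=O)(=O)c3ccc4ccccc4c3)c2CCN1CC1CCNCC1`, built on a different core, gives 310 nM. Going by the values given here, the one step within the shared core of compounds 1 and 2 is a 4.5-fold lower number from compound 1 to compound 2 (0.65 log units; beyond the scatter), a modest move.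

Compound 4 `CC(C)Cc1cc(CNS(=O)(=O)c2ccc(C(C)(C)C)cc2)nn1-c1ccccc1` carries the change (4-(tert-butyl)phenyl in place of naphthalen-1-yl on a sulfonyl sulfur). What enters matches what leaves in heavy-atom count but brings one aromatic ring where there were two. Among the compounds with values here, the only measured step that bears on this position is a 4.5-fold lower number from compound 1 to compound 2 (0.65 log units; beyond the scatter), in which a single chlorinated ring was exchanged for the two-ring group. Within the data shown here, compound 3 offers no step to this position, since its core and its sulfonyl group both differ.

Among the measured compounds shown here, compound 4 keeps the heavy-atom count of compound 2 but only one of its two aromatic rings, so the number is expected to move back toward that of compound 1 without reaching it, because a 4.5-fold lower number from compound 1 to compound 2 (0.65 log units; beyond the scatter) is the only guide and the present change undoes part of it. For compound 4 the estimate is 4500 nM, with a range from 1500 nM to 13000 nM, which is expected to mean a 1.9-fold higher number from compound 2 to compound 4 (0.27 log units; within the scatter).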

Compound 4, half-maximal inhibitory concentration: 8780 nM
Compound 4: middle estimate off by 2.0-fold (0.29 log units), on the low side, within the range that was stated.
By their numbers in this assay, from the lowest: compound 3; then compound 2; then compounds 4 and 1 (each within the scatter of the next).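

In this assay, the heavy-atom count alone does not hold the number at this position: naphthalen-1-yl and 4-(tert-butyl)phenyl match in that count but differ in aromatic rings, and the exchange gives a 3.6-fold higher number from compound 2 to compound 4 (0.56 log units; beyond the scatter). The two single-ring groups cannot be told apart, with a 1.2-fold lower number from compound 1 to compound 4 (0.09 log units; within the scatter), so on the shared core the two-ring group of compound 2 stands alone at the lower number, and neither compound 1 nor compound 4 goes against this, though three compounds make only a narrow basis. Nothing at hand accounts for this difference.

Whether the second aromatic ring itself matters, or only the way the same count of carbons is arranged on the sulfonyl sulfur, stays unsettled, as does the effect of a single phenyl ring carrying an amine or a carboxylic acid in place of the tert-butyl group. Steps from compound 3 to the other compounds cannot be read, since its core and its sulfonyl group both differ, so the shared core cannot be weighed against the aryl group.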